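Replacing 4-(dimethylamino)phenyl with 1H-indol-3-yl on the shared core

The source may report more compounds than this note shows. Statements on the series, on what has been measured and on what is new or still open speak of the compounds shown alone.

Compound 1 `Cc1ccc(S(=O)(=O)/C(=C/c2sccc2C)C(=O)c2ccc(Br)cc2)cc1` gives 25000 nM
Compound 2 `COc1ccc(/C=C(\C(=O)c2ccc(Br)cc2)S(=O)(=O)c2ccc(C)cc2)cc1` gives 1000 nM
Compound 3 `Cc1ccc(S(=O)(=O)/C(=C/c2ccc(N(C)C)cc2)C(=O)c2ccc(Br)cc2)cc1` gives 50000 nM

These numbers come from a functional assay on DU-145 cells (Homo sapiens) for inhibition, read by trypan blue exclusion, with a stated time of 96 h (a higher number here means a weaker inhibitor of growth, a lower number a stronger inhibitor of growth), and the three compounds differ only in one group on a double-bonded chain carbon bound to a double-bonded chain carbon. Compound 3 sits at the weak end of this short series. Two steps fix its place: a 2.0-fold higher number from compound 1 to compound 3 (0.30 log units; within the scatter) and a 50-fold higher number from compound 2 to compound 3 (1.70 log units; beyond the scatter) are its distances from the other two.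

The next structure is compound 4 `Cc1ccc(S(=O)(=O)/C(=C/c2c[nH]c3ccccc23)C(=O)c2ccc(Br)cc2)cc1` and the change is this: 1H-indol-3-yl in place of 4-(dimethylamino)phenyl on a double-bonded chain carbon bound to a double-bonded chain carbon at that same place. For the measured compounds named here, no measured compound carries this new group, so only swaps at this place can guide the expectation. They give a mixed picture: a 25-fold lower number from compound 1 to compound 2 (1.40 log units; beyond the scatter) shows that one swap can move the number a long way, while the step from compound 1 to compound 3 stays small. Compound 3 starts at 50000 nM so a lower number seems the likelier direction, though not a certain one. The expected move is a 5.0-fold lower number from compound 3 to compound 4 (0.70 log units; beyond the scatter) in this assay and this estimate is uncertain. Compound 4 is estimated at 10000 nM (expected range 2000 nM to 50000 nM).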

Compound 4, concentration for 50% growth inhibition: 10000 nM
For compound 4 middle estimate and measured number coincide at the digits printed; the range from low to high includes it.
By their numbers in this assay, from the lowest: compound 2; then compound 4; then compounds 1 and 3 (each within the scatter of the next).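

In this assay the step to 1H-indol-3-yl (a 5.0-fold lower number from compound 3 to compound 4 (0.70 log units; beyond the scatter)) and the comparison with the thiophene group (a 2.5-fold lower number from compound 1 to compound 4 (0.40 log units; beyond the scatter)) show that this place can hold a group that lies clear of both compound 1 and compound 3, two compounds within the scatter of each other. The two-ring group with its hydrogen-bond donor still falls short of the simpler 4-methoxyphenyl group (a 10-fold higher number from compound 2 to compound 4 (1.00 log units; beyond the scatter)), so compound 4 takes a middle rank in this set of four. No measurement on hand explains this order. Going by these compounds, whether the hydrogen on the indole nitrogen matters remains open, as a 1-methylindol-3-yl group would be needed to test it. Also open, on these data alone, is what a 4-hydroxyphenyl group would give at this place.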